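The source may report more compounds than this note shows. Statements on the series, on what has been measured and on what is new or still open speak of the compounds shown alone.

Of the compounds shown here, three have numbers so far in a physicochemical assay for activation, with a stated time of 60 min; a higher number here means that more compound is needed for the effect, a lower number that less compound is needed. Compound 1 (`NC(=O)N1C(=O)/C(=C(\O)c2ccc(Cl)s2)c2cc(Cl)ccc21`), built on a different core from the other two, gives 667000 nM. Compound 2 (`COc1cc(/C=C2\C(=O)NC(=O)C3=C2CCCC3)cc(OC)c1OC`) gives 500 nM. Compound 3 (`CCCCCc1ccc(/C=C2\C(=O)NC(=O)C3=C2CCCC3)cc1`) gives 9200 nM, which places it in the middle of the three, beyond the scatter from both compound 2 and compound 1.

Compound 4 (`O=C1NC(=O)/C(=C\c2ccc(F)cc2)C2=C1CCCC2`) keeps the core of compound 3, with fluoro in place of pentyl on an aromatic carbon. Among the measured compounds shown here, no measured pair differs in one place only, so this exchange has no direct precedent. Compound 2 and compound 3 share a core, but they differ at more than one place on the aromatic ring, so the gap between their values cannot be assigned to any single group. A moderate step towards a lower number is expected, beyond the scatter but with considerable uncertainty. The expected change is a 3.7-fold lower number from compound 3 to compound 4 (0.57 log units; beyond the scatter). For compound 4 the estimated value is 2500 nM, with an expected range of 500 nM to 12000 nM.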

Compound 4, half-maximal effective concentration: 60000 nM
Estimate against measurement, compound 4: 24-fold (1.38 log units) below, and the stated range ends below it.
By their numbers in this assay, from the lowest: compound 2; then compound 3; then compound 4; then compound 1.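

In this assay, among the compounds shown here, putting fluoro in place of pentyl on this aromatic carbon gives a 6.5-fold higher number from compound 3 to compound 4 (0.81 log units; beyond the scatter), the first step that can be read at a single place. With the shared core kept, the group at this carbon therefore matters beyond the scatter, and here the pentyl chain goes with less compound being needed than fluoro. Nothing available explains this step.

A single exchange cannot show whether the number follows the length of the carbon chain or instead reflects the change from a chain to a halogen. A methyl or propyl group, a longer chain such as heptyl, or chloro at the same carbon would help separate these two readings, while an amine or a carboxylic acid there would test how far the position tolerates other kinds of group.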